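The compounds below may be only part of what the source reports. "The series", "measured", "known", "first", "only" and "open" are said of these compounds alone.

Three compounds share one core, a bicyclic ketone carrying a sulfonyl group that is joined to a six-membered ring with two nitrogen atoms, and they differ only in the aromatic ring on the far amine nitrogen. Compound 1 `Cc1ccc(N2CCN(S(=O)(=O)C[C@]34CC[C@H](CC3=O)C4(C)C)CC2)nc1` was tested in a functional assay on CHO-K1 cells for antagonist activity at C-X-C chemokine receptor type 3 (Homo sapiens), read by FLIPR and calcium flux; on this read-out lower numbers stand for stronger inhibition and higher numbers for weaker inhibition. In this assay compound 1 gives > 31600 nM, which is a limit of the assay and not a number. Compound 1 therefore sits at the weak end of what has been seen here, as the limit of > 31600 nM in this assay, at which 1 of the 3 values shown sits, shows. Compound 2 `CC1(C)[C@@H]2CC[C@@]1(CS(=O)(=O)N1CCN(c3ncc(C(F)(F)F)cc3[N+](=O)[O-])CC1)C(=O)C2` gives 3160 nM in this assay. Compound 3 `CC1(C)[C@@H]2CC[C@@]1(CS(=O)(=O)N1CCN(c3ccc(C(F)(F)F)c(Cl)n3)CC1)C(=O)C2` gives 251 nM in this assay.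

Compound 4 `CC1(C)[C@@H]2CC[C@@]1(CS(=O)(=O)N1CCN(c3ncc(C(F)(F)F)cn3)CC1)C(=O)C2` has not yet been measured. It differs from compound 1 in one place: 5-(trifluoromethyl)pyrimidin-2-yl in place of 5-methylpyridin-2-yl on an amine nitrogen in a ring. Going by the values given here, the trifluoromethyl group that enters is also present in compound 2 and compound 3, both of which give numbers rather than limits, but neither of those pairs differs from compound 4 in only one place, so no measured step tells the size of this change directly.

The expectation is that the step from compound 1 to compound 4 will be toward stronger inhibition, an at least 12-fold lower number from compound 1 to compound 4 (1.10 log units; beyond the scatter). Compound 4 is estimated to give 2500 nM in this assay, expected to fall between 300 nM and 20000 nM.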

Compound 4, half-maximal inhibitory concentration: 316 nM
Compound 4: the middle estimate sits 7.9-fold (0.90 log units) above what was measured; the range from low to high includes it.
By their numbers in this assay, from the lowest: compounds 3 and 4 (each within the scatter of the next); then compound 2. At a limit, above all of these: compound 1.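

In this assay, the aromatic ring on the amine nitrogen decides a great deal with the rest of the molecule unchanged: putting 5-(trifluoromethyl)pyrimidin-2-yl in place of 5-methylpyridin-2-yl gives an at least 100-fold lower number from compound 1 to compound 4 (2.00 log units; beyond the scatter). Going by these compounds alone, this is the first measured pair that differs in one place only, so it gives the first direct view of how much this position can matter, which compounds 1, 2 and 3 could not give when compared with one another. The true size of the step may be larger still, since compound 1 stands at a limit of the assay and not at a number: the limit of > 31600 nM in this assay, at which 1 of the 4 values shown sits.

Going by these compounds, the change replaces two things at once, the methyl group with a trifluoromethyl group and the ring with one holding a second nitrogen, so it remains open whether 5-(trifluoromethyl)pyridin-2-yl or 5-methylpyrimidin-2-yl would account for most of the step. On these data alone, it also remains open how a nitrile or a methoxy group in place of the trifluoromethyl group would read out on this ring, and no cause for the step can be drawn from these compounds.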